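The source may hold more compounds than are shown below. What is called first, only, known or untested is meant among the compounds shown, and "the series" means these compounds.

Measured compounds:
compound 1 `COc1cc(C(=O)c2cccc3[nH]ccc23)cc(OC)c1OC` gives 50.7 nM in a functional assay on KB cells (Homo sapiens) for inhibition, with a stated time of 72 h; on this read-out higher numbers stand for weaker inhibition and lower numbers for stronger inhibition
compound 2 `COc1cc(C(=O)c2ccc3[nH]ccc3c2)cc(OC)c1OC` gives 104 nM in this assay
compound 3 `COc1cc(C(=O)c2ccc3c(ccn3C(C)C)c2)cc(OC)c1OC` gives 1800 nM in this assay

Among these three numbers in this assay, compound 2 stands second highest. Its nearest neighbour is compound 1, whose number is lower, beyond the scatter; its furthest is compound 3, whose number is far higher. Compound 4 `COc1cc(C(=O)c2ccc3c(ccn3CC(=O)O)c2)cc(OC)c1OC` differs from compound 2 in one place: carboxymethyl in place of hydrogen on an aromatic nitrogen.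

Among the compounds with values here, only one measured step bears on this change, the one at the same aromatic nitrogen, where a 17-fold higher number from compound 2 to compound 3 (1.24 log units; beyond the scatter). Within the data shown here, the group entering in compound 4 is different from the isopropyl of compound 3, but it occupies the same position, and the one precedent is a large rise in the number. Among the measured compounds shown here, a step of similar direction is therefore expected, a 14-fold higher number from compound 2 to compound 4 (1.16 log units; beyond the scatter), with wide uncertainty because the only guide is a 17-fold higher number from compound 2 to compound 3 (1.24 log units; beyond the scatter).

Compound 4 is thus estimated at 1500 nM in this assay, within a range from 300 nM to 8000 nM.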

Compound 4, half-maximal inhibitory concentration: 520 nM
For compound 4 the middle estimate is 2.9-fold (0.46 log units) above the measured one; measured number inside the range.
By their numbers in this assay, from the lowest: compound 1; then compound 2; then compound 4; then compound 3.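

In this assay, a second group on the aromatic nitrogen also raises the number, with a 5.0-fold higher number from compound 2 to compound 4 (0.70 log units; beyond the scatter), so among the compounds shown, both substituents at this place stand above the hydrogen of compound 2. The size of the rise is not fixed by the position alone: carboxymethyl in place of isopropyl gives a 3.5-fold lower number from compound 3 to compound 4 (0.54 log units; beyond the scatter), which shows that the group entering matters as well as the fact of substitution. No measurement given here accounts for the gap between these two groups.

On these data alone, whether a methyl, a chain carrying an amine, or the methyl ester of the carboxymethyl group would stand nearer to compound 2 or to compound 3 remains open. As far as these compounds go, it is also open whether the same groups on the nitrogen of compound 1 would give steps of similar size.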